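The source may hold more compounds than are shown below. What is called first, only, known or untested is meant among the compounds shown, and "the series" means these compounds.

For the measured compounds named here, compound 2 `O=C(NCc1ccc(S(=O)(=O)c2cccc(C(F)(F)F)c2)cc1)N1Cc2ccncc2C1` gives 8 nM in an assay on isolated protein for inhibition of Nicotinamide phosphoribosyltransferase (Homo sapiens), read by mass spectrometry, with stated times of 15 min and 30 min (on this read-out lower numbers stand for stronger inhibition and higher numbers for weaker inhibition), the lower of the two numbers measured so far. Compound 1 `O=C(NCc1ccc(S(=O)(=O)c2ccccc2)cc1)N1Cc2cccnc2C1` gives 60 nM in this assay. Compound 3 `CCCn1cc(S(=O)(=O)c2ccc(CNC(=O)N3Cc4ccncc4C3)cc2)cn1` differs from compound 2 in one place: 1-propyl-1H-pyrazol-4-yl in place of 3-(trifluoromethyl)phenyl on a sulfonyl sulfur. Going by the values given here, no measured pair shows what this exchange does on its own, so the expectation rests only on the values of compound 1 and compound 2. Compound 3 is expected to give about 20 nM, somewhere between 6 nM and 70 nM. The estimated step of a 2.5-fold higher number from compound 2 to compound 3 (0.40 log units; beyond the scatter) is a mild weakening that could still fall within the usual scatter.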

Compound 3, half-maximal inhibitory concentration: 17 nM
Beside the measured number, compound 3's estimate is 1.2-fold (0.07 log units) above it, and the stated range covers the measured number.
By their numbers in this assay, from the lowest: compound 2; then compound 3; then compound 1.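

Placing 1-propyl-1H-pyrazol-4-yl on the sulfonyl sulfur instead of 3-(trifluoromethyl)phenyl gives in this assay only a modest change, a 2.1-fold higher number from compound 2 to compound 3 (0.33 log units; beyond the scatter), so a six-membered ring of carbon only is not required at this position for a low number. No measurement given explains this step. For the compounds shown here, whether the propyl chain contributes remains open, since no compound here carries a methyl group, a longer chain or an amine on that ring. From the compounds shown here alone, compound 1 differs from compound 2 in more than one place, so the trifluoromethyl group's own contribution also remains unknown.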